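The compounds below may be only part of what the source reports. "The series", "measured", "known", "first", "only" and "open" are said of these compounds alone.

Measured so far:
- compound 1, `Cc1ccc(NC2=C/C(=N/NC(N)=S)C(=O)N=C2Nc2ccc(C)cc2)cc1`: 3060 nM
- compound 2, `NC(=S)N/N=C1/C=C(Nc2cccc(Cl)c2)C(Nc2cccc(Cl)c2)=NC1=O`: 630 nM
- compound 3, `NC(=S)N/N=C1/C=C(Nc2cccc([N+](=O)[O-])c2)C(Nc2cccc([N+](=O)[O-])c2)=NC1=O`: 11100 nM

All three share one core and differ in the two aryl groups on it. In a functional assay on MCF7 cells (Homo sapiens) for antiproliferative activity, read by MTT assay, with a stated time of 72 h (a lower number here means a stronger inhibitor, a higher number a weaker inhibitor), compound 2 gives 630 nM and holds the lowest number of the three. Compound 1 gives 3060 nM, a gap that lies beyond the scatter, and compound 3 gives 11100 nM, the furthest of the set. Both comparisons are between compounds that differ in the aryl groups, not in the thiosemicarbazone part.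

Compound 4, `N/C(=N\N=C1\C=C(Nc2cccc(Cl)c2)C(Nc2cccc(Cl)c2)=NC1=O)SCc1ccccc1`, keeps the two aryl groups of compound 2 and changes the other end: a group of 11 heavy atoms (8 carbon, 2 nitrogen, 1 sulfur; one six-membered aromatic ring of carbon only) in place of a group of 4 heavy atoms (1 carbon, 2 nitrogen, 1 sulfur; no ring), on a double-bonded nitrogen. Among the measured compounds shown here, no measured pair shows a change at this position, so the size of the step has no precedent here. The added ring and the loss of one donor are the only facts to go on. In this assay a moderate step toward a higher number is expected for compound 4, though a step within the scatter cannot be ruled out.

Compound 4 is therefore estimated at 1100 nM, within 350 nM to 3500 nM, which is an expected step of a 1.7-fold higher number from compound 2 to compound 4 (0.24 log units; within the scatter).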

Compound 4, half-maximal inhibitory concentration: 15200 nM
Estimate against measurement, compound 4: 14-fold (1.14 log units) below, outside the stated range (above it).
By their numbers in this assay, from the lowest: compound 2; then compound 1; then compounds 3 and 4 (each within the scatter of the next).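

The thiosemicarbazone end of the series is not a neutral site: with the aryl groups of compound 2 held fixed, the change on the double-bonded nitrogen gives a 24-fold higher number from compound 2 to compound 4 (1.38 log units; beyond the scatter) in this assay. Among the compounds shown here, until now, every difference among the measured compounds lay in the aryl groups, so this is the first reading of how far the number can move at the other end, and the move is large. For the compounds shown here, the single step bundles several changes, as the entering group brings one six-membered aromatic ring of carbon only, 1 hydrogen-bond donor in place of 2, and 2 hydrogen-bond acceptors in place of 1, and no measurement at hand bears on which of these matters or why the number rises.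

A smaller entering group, with a methyl in place of the aromatic ring, would show whether the ring or the rest of the change carries the step. Going by these compounds alone, whether a step of this size also appears with the aryl groups of compound 1 or compound 3 remains open, since the only pair at this position has the aryl groups of compound 2.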